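The source may hold more compounds than are shown below. What is called first, only, known or untested is meant among the compounds shown, and "the series" means these compounds.

Measured so far in this series:

compound 1, `COc1cccc(-c2nn(-c3ccccc3)cc2-c2ccnc(NCCNC(=O)Nc3cccc(C(F)(F)F)c3)c2)c1`: 100000 nM
compound 2, `COc1cccc(-c2nn(-c3ccccc3)cc2-c2ccnc(NCCCNC(=O)Nc3ccc(Cl)c(Cl)c3)c2)c1`: 86900 nM
compound 3, `O=C(NCCCNc1cc(-c2cn(-c3ccccc3)nc2-c2cccc(O)c2)ccn1)c1ccccc1`: 100000 nM

All three numbers come from a functional assay on NCI/ADR-RES cells (Homo sapiens) for cytotoxicity; on this read-out higher numbers stand for lower toxicity in this test and lower numbers for higher toxicity in this test. In this assay compound 3 gives 100000 nM, the same number as compound 1 gives, and compound 2 differs from compound 3 only by an amount that lies within the usual scatter of this assay. The three measured compounds therefore sit together, none apart from the others, with compound 3 and compound 1 sharing the highest of the three readings.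

Compound 4, `O=C(NCCCNc1cc(-c2cn(-c3ccccc3)nc2-c2cccc(O)c2)ccn1)c1ccc(F)cc1`, is not yet measured in this assay. It differs from compound 3 in a single place: fluoro in place of hydrogen on an aromatic carbon. Cut one bond further out, the same difference reads phenyl to 4-fluorophenyl, benzoyl to (4-fluorophenyl)carbonyl, benzamido to ((4-fluorophenyl)carbonyl)amino. Within the data shown here, no pair of measured compounds shows this exchange on its own, so nothing among the three numbers sizes it, and the three numbers give no direction either.

The expected step for this exchange is no change at the digits printed from compound 3 to compound 4 (within the scatter), which is to say none beyond the scatter of this assay. On that basis compound 4 is estimated to give 100000 nM in this assay, within a range from 50000 nM to 150000 nM.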

Compound 4, concentration lethal to 50% of the cells: 29700 nM
The estimate for compound 4 lay 3.4-fold (0.53 log units) above the measured number, outside the stated range (below it).
By their numbers in this assay, from the lowest: compound 4; then compounds 2, 1 and 3 (each within the scatter of the next).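

In this assay, fluoro in place of hydrogen on an aromatic carbon, para to a large group, gives a 3.4-fold lower number from compound 3 to compound 4 (0.53 log units; beyond the scatter). Among these compounds, this is the only step so far that isolates a single change, and it shows that this position of the benzamido phenyl ring is not silent: one added heavy atom, turning phenyl into 4-fluorophenyl, is enough to move the reading beyond the scatter, in the direction of higher toxicity in this test. Nothing available accounts for the size or direction of this step.

From the compounds shown here alone, it remains open whether the step is specific to fluoro or would also appear with another group at the same carbon, such as methyl, nitrile or an amine. Going by these compounds, it is equally open whether the same exchange would give a comparable step on a different background, for example with a longer chain in place of the present one or with the urea linkage of the other compounds in place of the amide.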